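Swapping piperidin-4-yl for 1-methylpyrrolidin-3-yl

The compounds below may be only part of what the source reports. "The series", "measured", "known", "first", "only" and "open" are said of these compounds alone.

For the measured compounds named here, in an ADME assay on Caco-2 cells (Homo sapiens) for permeability (on this read-out lower numbers stand for lower permeability and higher numbers for higher permeability), compound 2 (`Cc1cc2ncccc2cc1Nc1ncc2c(n1)n(C1CCNCC1)c(=O)n2C`) gives 0.7 10^-6 cm/s as the lower of the two numbers measured so far, while compound 1 (`Cc1cc2ncccc2cc1Nc1ncc2c(n1)n(C1CCN(C)CC1)c(=O)n2C`) gives 14 10^-6 cm/s on the same scale. Going by the values given here, the only measured step is a 20-fold lower number from compound 1 to compound 2 (1.30 log units; beyond the scatter) and it comes with hydrogen in place of methyl on an amine nitrogen in a ring. Compound 3 (`Cc1cc2ncccc2cc1Nc1ncc2c(n1)n([C@H]1CCN(C)C1)c(=O)n2C`) has 1-methylpyrrolidin-3-yl in place of piperidin-4-yl on an aromatic nitrogen and so carries a methyl on its ring amine nitrogen, as compound 1 does, but in a five-membered non-aromatic ring. Among the compounds with values here, no measured compound shows what that ring alone does. The nearest guide is therefore compound 1 at 14 10^-6 cm/s and a rise beyond the scatter is expected in this assay for the new ring. The expected change is a 14-fold higher number from compound 2 to compound 3 (1.15 log units; beyond the scatter) and it remains an estimate. For compound 3 the estimated value is 10 10^-6 cm/s and 3 10^-6 cm/s to 25 10^-6 cm/s is the expected range.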

Compound 3, apparent permeability: 19 10^-6 cm/s
Estimate against measurement, compound 3: 1.9-fold (0.28 log units) below, within the range that was stated.
By their numbers in this assay, from the lowest: compound 2; then compounds 1 and 3 (each within the scatter of the next).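

Rearranging the same atoms into 1-methylpyrrolidin-3-yl gives a 27-fold higher number from compound 2 to compound 3 (1.43 log units; beyond the scatter) in this assay on an aromatic nitrogen, so the low number of compound 2 does not follow from the atom count at this place. The ring size can now be read apart from the methyl: a 1.4-fold higher number from compound 1 to compound 3 (0.13 log units; within the scatter) is a step within the scatter, and on this read-out the five-membered and six-membered rings cannot be told apart when each carries a methyl on its ring nitrogen. No supporting data offer an explanation for these numbers.

The compounds shown leave open whether pyrrolidin-3-yl, with a hydrogen on its ring nitrogen, would fall as compound 2 does. Also open, going by these compounds, are the mirror-image form of compound 3 and a longer chain such as ethyl on the ring nitrogen.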